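This account rests on a few compounds, and the source may have more. Where it says the series, first, only, none or still open, it means among the compounds named here.

Measured compounds:
compound 1 `OC(CCn1nc2c(Br)c(Br)c(Br)c(Br)c2n1)c1cccc(Br)c1`, 102%;
compound 2 `OC(CCn1nc2c(Br)c(Br)c(Br)c(Br)c2n1)c1ccc(F)cc1`, 109%;
compound 3 `OC(CCn1nc2c(Br)c(Br)c(Br)c(Br)c2n1)c1ccc(Br)cc1`, 107%.

In a functional assay on MCF7 cells (Homo sapiens) for antiproliferative activity, read by MTT assay, with a stated time of 48 h, tested at 12.5 uM (on this read-out higher numbers stand for a weaker effect at the one concentration tested and lower numbers for a stronger effect), compound 3 gives 107%, the second highest of the three numbers. Its nearest neighbour is compound 2, with a number 2 percentage points lower from compound 2 to compound 3 (within the scatter); the furthest is compound 1, with a number 5 percentage points higher from compound 1 to compound 3 (within the scatter). Compound 4 `OC(CCn1nc2c(Br)c(Br)c(Br)c(Br)c2n1)c1ccc(Cl)cc1` is the next member of the series, and it differs from compound 3 by one change: chloro in place of bromo on an aromatic carbon. The step that bears most directly on this is the swap of one halogen for another on the same aromatic carbon, a number 2 percentage points lower from compound 2 to compound 3 (within the scatter), which stayed inside the usual scatter, as did the moves between compounds 1, 2 and 3 generally. Compound 4 is therefore expected to show no step beyond the scatter, a number 2 percentage points lower from compound 3 to compound 4 (within the scatter). Compound 4 is estimated at 105%, in the range 95% to 115%.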

Compound 4, a percentage reported as activity, at one concentration (the size of the read-out at that concentration, not a potency): 100%
Compound 4: the middle estimate sits 5 percentage points above what was measured; measured number inside the range.
By their numbers in this assay, from the lowest: compounds 4, 1, 3 and 2 (each within the scatter of the next).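

In this assay a third halogen on this aromatic carbon brings no separation: chloro in place of bromo gives a number 7 percentage points lower from compound 3 to compound 4 (within the scatter) and chloro in place of fluoro gives a number 9 percentage points lower from compound 2 to compound 4 (within the scatter) so the three halogens at this place read alike. The 4-chlorophenyl in place of 3-bromophenyl gives a number 2 percentage points lower from compound 1 to compound 4 (within the scatter) and also stays inside the scatter. Nothing measured here bears on why these numbers read as they do.

The compounds shown leave open whether a non-halogen group on this carbon, such as methoxy or an amine, would give a step beyond the scatter. They also leave open what a longer chain would do.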